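Exchanging the chain amine for a cyclic group

This account rests on a few compounds, and the source may have more. Where it says the series, first, only, none or still open, it means among the compounds named here.

Compound 1 `Cc1nc(NCCNS(C)(=O)=O)nc2ccc(NC(=O)/C=C/c3ccc(OC(F)(F)F)cc3)cc12`: 142 nM
Compound 2 `C/C(=C\C(=O)Nc1ccc2nc(N3CCC(O)(C4CC4)CC3)nc(C)c2c1)c1ccc(Cl)cc1`: 340 nM
Compound 3 `COc1ccc(/C=C/C(=O)Nc2ccc3nc(N4CCC(O)(C5CC5)CC4)nc(C)c3c2)cc1`: 59 nM

In a functional assay on CHO-K1 cells for antagonist activity at melanin-concentrating hormone receptor 1 (Homo sapiens), read by inositol phosphate accumulation, with stated times of 10 min and 45 min (on this read-out higher numbers stand for weaker inhibition and lower numbers for stronger inhibition), compound 1 stands second highest of the three numbers, with compound 2 giving a higher number and compound 3 a lower one. Compound 4 `Cc1nc(N2CCC(N3CCOC3=O)CC2)nc2ccc(NC(=O)/C=C/c3ccc(OC(F)(F)F)cc3)cc12` has not yet been measured in this assay. It differs from compound 1 in one place: 4-(2-oxo-1,3-oxazolidin-3-yl)piperidin-1-yl in place of (2-(methanesulfonamido)ethyl)amino on an aromatic carbon.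

For the measured compounds named here, the only measured step, a 5.8-fold lower number from compound 2 to compound 3 (0.76 log units; beyond the scatter), concerns the group on the carbonyl carbon, not the position changed here, so it does not bear directly on the step from compound 1 to compound 4. Compounds 2 and 3 do carry a ring-bearing group at the same aromatic carbon, and there compound 2 gives 340 nM while compound 3 gives 59 nM; the amide portion of compound 4 is that of compound 1. With no direct comparison, compound 4 is expected to stay near compound 1, so the step of a 1.4-fold lower number from compound 1 to compound 4 (0.15 log units; within the scatter) is estimated to lie within or only slightly beyond the scatter. Compound 4 is therefore estimated at 100 nM, with a range from 30 nM to 330 nM.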

Compound 4, half-maximal inhibitory concentration: 31 nM
Compound 4: the middle estimate sits 3.2-fold (0.51 log units) above what was measured; the measured number falls inside the stated range.
By their numbers in this assay, from the lowest: compounds 4 and 3 (each within the scatter of the next); then compound 1; then compound 2.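

In this assay the step at the aromatic carbon between two ring nitrogen atoms, a 4.6-fold lower number from compound 1 to compound 4 (0.66 log units; beyond the scatter), shows that this position does not depend on the open (2-(methanesulfonamido)ethyl)amino chain. A larger group with two non-aromatic rings and no hydrogen-bond donors, 4-(2-oxo-1,3-oxazolidin-3-yl)piperidin-1-yl, takes its place with the number falling beyond the scatter, so the sulfur-bearing chain and its donors are not required in this pair. Nothing measured here accounts for the gain.

For the compounds shown here, both rings enter in the single step, so the compounds leave open whether the oxazolidinone ring contributes or a plain piperidine would read the same. From the compounds shown here alone, how a morpholine or a piperazine with a free amine would read at this carbon also remains unknown.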